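From acetyl to ethoxycarbonyl: expected cytotoxicity of compound 4

The source may report more compounds than this note shows. Statements on the series, on what has been measured and on what is new or still open speak of the compounds shown alone.

Compound 1 `c1ccc(-c2ccc(Cn3cncc3CNc3ccc(-c4onc5ccccc45)c(-c4ccccc4)c3)cc2)cc1` in a toxicity assay on NIH3T3 cells (Mus musculus) for cytotoxicity, read by resazurin assay; on this read-out lower numbers stand for an effect already at smaller amounts and higher numbers for an effect only at larger amounts of compound: > 10000 nM
Compound 2 `O=C(c1ccc(NCc2cncn2Cc2ccc(-c3ccccc3)cc2)cc1-c1ccccc1)N1CCCCC1` in this assay: > 1000 nM
Compound 3 `CC(=O)c1ccc(NCc2cncn2Cc2ccc(-c3ccccc3)cc2)cc1-c1ccccc1` in this assay: > 10000 nM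

None of the three values is a number; each is a limit of the assay. Compound 3 sits at the limit of > 10000 nM in this assay, at which 2 of the 3 values shown sit. Compound 1 also sits at that limit. Compound 2 sits at the limit of > 1000 nM in this assay, at which 1 of the 3 values shown sits. The three steps among the measured compounds, a step that the two limits leave unreadable from compound 1 to compound 2, a step that the two limits leave unreadable from compound 1 to compound 3 and a step that the two limits leave unreadable from compound 2 to compound 3, therefore cannot be read; the limits hide their size and direction.

Compound 4 `CCOC(=O)c1ccc(NCc2cncn2Cc2ccc(-c3ccccc3)cc2)cc1-c1ccccc1` differs from compound 3 in one place: ethoxy in place of methyl on a carbonyl carbon. Within the data shown here, the only measured step at the same carbonyl carbon is the one from compound 2 to compound 3, and it is unreadable, so no measured step gives a size to expect for the new change. With compound 3 itself at a limit, the expectation is that compound 4 will again reach only that limit, and the step that the limit leaves unreadable from compound 3 to compound 4 is estimated as none that could be read. Compound 4 is therefore estimated at 20000 nM in this assay, with a range from 8000 nM to 60000 nM.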

Compound 4, half-maximal effective concentration: > 10000 nM
Compound 4 was reported as a limit (the forecaster's own chance of this, stated with the estimate: 85%); the middle value is on the limit's open side.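

In this assay compound 4 gives > 10000 nM, which is a limit and not a number. Among these compounds, no step linking compound 4 to compound 1, compound 2 or compound 3 can be read. The compounds shown leave open what numerical value any of them would reach in this assay, and so whether ethoxy in place of methyl on the carbonyl carbon changes it at all.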